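Ethylamino to Isopropylamino: One More Methyl on the Amide

A few compounds are considered here, and "the series" means these few. Any claim that something is new, unique, unknown or untested is made for them only; others in the source may bear on it.

Measured compounds:
compound 1 `CNC(=O)CC1CCc2cc(OC)c(OC)cc21`: 29%
compound 2 `COc1cc2c(cc1OC)C(CC(=O)N(C)C)CC2`: 34.8%
compound 3 `CCNC(=O)CC1CCc2cc(OC)c(OC)cc21`: 26.1%

All three share one core and differ only in the amide group. In a functional assay on the whole organism (strain Wistar) for inhibition, with Rattus norvegicus as the target, read by paw edema, with stated times of 60 min and 3 h, at a dose of 100 mg/kg by the oral route (on this read-out lower numbers stand for less inhibition and higher numbers for more inhibition at the one dose given (going by the name of the read-out)), compound 3 gives 26.1%. On the numbers shown it stands at the low end of the three, but neither gap is meaningful: a number 2.9 percentage points lower from compound 1 to compound 3 (within the scatter) and a number 8.7 percentage points lower from compound 2 to compound 3 (within the scatter), both within the scatter.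

Compound 4 `COc1cc2c(cc1OC)C(CC(=O)NC(C)C)CC2` is the next member. Its change from compound 3 is methyl in place of hydrogen on a saturated chain carbon bound to an amide-type nitrogen and a saturated chain carbon. The step that bears most on it is the earlier addition of a methyl on the same kind of chain carbon, a number 2.9 percentage points lower from compound 1 to compound 3 (within the scatter), which stayed within the scatter, as did the methyl added on the amide nitrogen, a number 5.8 percentage points higher from compound 1 to compound 2 (within the scatter). Each extra methyl so far has left the read-out unchanged, so no step beyond the scatter is expected here either.

Compound 4 is therefore estimated to give 27%, with a range from 15% to 40%. The expected step of a number 0.9 percentage points higher from compound 3 to compound 4 (within the scatter) lies within the scatter.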

Compound 4, a percentage reported as inhibition, in the whole organism at one dose (the size of the read-out at that dose, not a potency): 30.4%
Estimate against measurement, compound 4: 3.4 percentage points below; the range from low to high includes it.
By their numbers in this assay, from the lowest: compounds 3, 1, 4 and 2 (each within the scatter of the next).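

Replacing ethylamino with isopropylamino adds a methyl on the saturated chain carbon bound to the amide-type nitrogen, and in this assay the outcome is a number 4.3 percentage points higher from compound 3 to compound 4 (within the scatter) for this single added carbon. The isopropylamino group also stays close to the other two amides, with a number 4.4 percentage points lower from compound 2 to compound 4 (within the scatter) and a number 1.4 percentage points higher from compound 1 to compound 4 (within the scatter) as its steps, so at this one dose no two of the four amide groups shown can be told apart. No measurement here offers an explanation for these numbers.

As far as these compounds go, whether a larger group on the amide nitrogen, such as a benzyl or a cyclohexyl group, would give a step beyond the scatter remains open. The same question stands for a carboxylic acid in place of the amide.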